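A few compounds are considered here, and "the series" means these few. Any claim that something is new, unique, unknown or untested is made for them only; others in the source may bear on it.

For the measured compounds named here, compound 2 `CC1=C(N2CC2)C(=O)C(N2CC2)=C(N2CC2)C1=O` stands highest of the two numbers so far in a functional assay on L1210 cells (Mus musculus), with a stated time of 1 days (on this read-out lower numbers stand for lower potency and higher numbers for higher potency (the scale is a negative logarithm)), where compound 2 gives 5.69; compound 1 `CC1=C(N2CC2)C(=O)C(C(C)C)=C(N2CC2)C1=O` gives 4.69, beyond the scatter below it. Going by the values given here, the single measured step, a number 1.00 log units higher from compound 1 to compound 2 (beyond the scatter), is the only one that bears on the change to compound 3 `CC(=O)C1=C(N2CC2)C(=O)C(C)=C(N2CC2)C1=O`, which is acetyl in place of aziridin-1-yl on a double-bonded ring carbon. Compound 3 loses the kind of group whose entry made that step, so a step of similar size in the opposite direction is expected, a number 0.89 log units lower from compound 2 to compound 3 (beyond the scatter), beyond the scatter. In this assay compound 3 is therefore estimated at 4.8, with a range from 4.2 to 5.4.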

Compound 3, logarithm of the reciprocal of the active concentration, log(1/C): 3.48
The estimate for compound 3 lay 1.32 log units above the measured number; measured number below the stated range.
By their numbers in this assay, from the lowest: compound 3; then compound 1; then compound 2.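

In this assay acetyl on this double-bonded ring carbon gives a number 2.21 log units lower from compound 2 to compound 3 (beyond the scatter) when it replaces aziridin-1-yl and a number 1.21 log units lower from compound 1 to compound 3 (beyond the scatter) when it replaces isopropyl. The position therefore separates more than aziridin-1-yl from everything else: the two groups without that ring also differ, with acetyl lowest and isopropyl in the middle. Nothing at hand accounts for the difference between acetyl and isopropyl.

Open, from the compounds shown here alone, is where a simple amine such as dimethylamino, a methoxy group or a longer alkyl chain would fall at this carbon. Also open, going by these compounds, is whether another carbonyl group, such as an ester, would track acetyl.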